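A few compounds are considered here, and "the series" means these few. Any claim that something is new, unique, unknown or untested is made for them only; others in the source may bear on it.

Measured compounds:
- compound 1, `COc1cc(NC(=O)c2ccc(C)c(C#Cc3cc(-c4cnn(C)c4)cnc3N)c2)cc(OC)c1`: 397 nM
- compound 2, `Cc1ccc(C(=O)Nc2ccc(Cl)cc2)cc1C#Cc1cc(-c2cnn(C)c2)cnc1N`: 269 nM
- compound 3, `Cc1ccc(C(=O)Nc2ccc(C(F)(F)F)cc2)cc1C#Cc1cc(-c2cnn(C)c2)cnc1N`: 14 nM

In an ADME assay on RBL-2H3 cells (Rattus norvegicus) for cytotoxicity, read by CCK-8 assay, with a stated time of 24 h (on this read-out lower numbers stand for higher toxicity in this test and higher numbers for lower toxicity in this test), compound 2 gives 269 nM, the second highest of the three numbers. Its nearest neighbour is compound 1 at 397 nM, a step that is a 1.5-fold lower number from compound 1 to compound 2 (0.17 log units; within the scatter). Compound 3 lies furthest away at 14 nM, and the step is a 19-fold lower number from compound 2 to compound 3 (1.28 log units; beyond the scatter); from compound 1 the corresponding step is a 28-fold lower number from compound 1 to compound 3 (1.45 log units; beyond the scatter).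

Compound 4, `Cc1ccc(C(=O)Nc2cccc(OC(F)(F)F)c2)cc1C#Cc1cc(-c2cnn(C)c2)cnc1N`, is not yet measured. It differs from compound 2 in one place: 3-(trifluoromethoxy)phenyl in place of 4-chlorophenyl on an amide-type nitrogen.

Within the data shown here, the step that bears most directly on this change is the one from compound 2 to compound 3, where a trifluoromethyl group in place of chloro on the aromatic carbon gave a large drop in this assay. Among the measured compounds shown here, compound 4 carries a trifluoromethoxy group rather than trifluoromethyl, and it sits at a different position of the ring; no measured pair shows exactly that change, so the expectation is a drop of intermediate size rather than one as large as a 19-fold lower number from compound 2 to compound 3 (1.28 log units; beyond the scatter). The expected step from compound 2 to compound 4 is therefore a 4.5-fold lower number from compound 2 to compound 4 (0.65 log units; beyond the scatter). Compound 4 is estimated at 60 nM, with a range from 15 nM to 270 nM.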

Compound 4, half-maximal cytotoxic concentration: 33.7 nM
For compound 4 the middle estimate is 1.8-fold (0.25 log units) above the measured one; measured number inside the range.
By their numbers in this assay, from the lowest: compound 3; then compound 4; then compounds 2 and 1 (each within the scatter of the next).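

In this assay, 3-(trifluoromethoxy)phenyl on the amide-type nitrogen gives an 8.0-fold lower number from compound 2 to compound 4 (0.90 log units; beyond the scatter) and a 12-fold lower number from compound 1 to compound 4 (1.07 log units; beyond the scatter), so among the compounds shown, a low number at this position is not confined to the 4-(trifluoromethyl)phenyl group. The two fluorinated groups still differ, with a 2.4-fold higher number from compound 3 to compound 4 (0.38 log units; beyond the scatter), and so the change from one to the other is itself beyond the scatter. Nothing available here explains these differences.

The shared change of substituent and ring position leaves open which of the two accounts for the difference, a question that 3-(trifluoromethyl)phenyl or 4-(trifluoromethoxy)phenyl on the same nitrogen would address. Also open, going by these compounds, is how this read-out would respond to a phenyl ring bearing an amine or a carboxylic acid at this position.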